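A Methanesulfonamide in Place of a Hydroxyethyl Arm

A few compounds are considered here, and "the series" means these few. Any claim that something is new, unique, unknown or untested is made for them only; others in the source may bear on it.

Compound 1 `O=C(O)CC/C=C\CO[C@H]1C(OCc2ccc(-c3ccccc3)cc2)CC[C@@H]1N1CCCCCC1`: 12.6 nM
Compound 2 `O=C(O)CC/C=C\CO[C@@H]1C(OCc2ccc(-c3ccccc3)cc2)CC[C@@H]1N1CCCCC1`: 39.8 nM
Compound 3 `O=C(O)CC/C=C\CO[C@H]1C(OCc2ccc(-c3ccccc3CCO)cc2)CC[C@@H]1N1CCCCCC1`: 2 nM

Three compounds share a cyclopentane core carrying a hexenoic acid chain, a biphenylmethoxy group and a cyclic amine, and were measured in a functional assay on blood for antagonist activity at thromboxane A2 receptor (Homo sapiens); a higher number here means weaker binding, a lower number tighter binding. Compound 3 gives the lowest number of the three; its nearest neighbour is compound 1, and compound 2 stands furthest from it. Among the compounds with values here, the one step that can be read between these compounds is a 6.3-fold lower number from compound 1 to compound 3 (0.80 log units; beyond the scatter), which shows that a substituent on the outer phenyl ring is tolerated and helpful.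

Compound 4 `CS(=O)(=O)Nc1ccccc1-c1ccc(COC2CC[C@H](N3CCCCCC3)[C@H]2OC/C=C\CCC(=O)O)cc1` keeps everything of compound 3 but differs at that same aromatic carbon: methanesulfonamido in place of 2-hydroxyethyl on an aromatic carbon. Within the data shown here, no measured pair here involves a methanesulfonamido group, so the only guidance is that the substituted position has already accepted a group of comparable size in compound 3, reached through a 6.3-fold lower number from compound 1 to compound 3 (0.80 log units; beyond the scatter). On that basis the expected step is small, a 1.3-fold lower number from compound 3 to compound 4 (0.10 log units; within the scatter), and compound 4 is estimated at 1.6 nM in this assay, within a range of 0.5 nM to 5 nM.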

Compound 4, dissociation constant: 10 nM
Beside the measured number, compound 4's estimate is 6.3-fold (0.80 log units) below it, outside the stated range (above it).
By their numbers in this assay, from the lowest: compound 3; then compounds 4 and 1 (each within the scatter of the next); then compound 2.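

At this aromatic carbon, this assay separates the two substituents: replacing 2-hydroxyethyl with methanesulfonamido gives a 5.0-fold higher number from compound 3 to compound 4 (0.70 log units; beyond the scatter) and so loses most of what the 2-hydroxyethyl group had gained. Measured against the unsubstituted compound, the methanesulfonamido group gives a 1.3-fold lower number from compound 1 to compound 4 (0.10 log units; within the scatter) within the scatter, so it is tolerated at this position but brings no readable benefit, and a substituent here does not improve the number merely by being present. The two groups differ in their atoms and heavy-atom counts, but nothing available connects the step to any one of those differences.

The compounds shown leave open whether the benefit of 2-hydroxyethyl depends on its terminal hydroxyl or on the two-carbon chain that carries it, a question that a 3-hydroxypropyl chain, a carboxylic acid or an amine at the same carbon could help answer. They also leave open whether a methanesulfonamido group would behave the same way at another carbon of that ring, or with a different cyclic amine on the shared core.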